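The source may hold more compounds than are shown below. What is called first, only, known or untested is meant among the compounds shown, and "the series" means these compounds.

Compound 1 `COc1cc(OC)c(OC)cc1/C=C/COC(=O)/C=C/c1c(OC)ccc(OC)c1OC`: >= 180 umol/kg, a limit
Compound 2 `COc1cc(OC)c(OC)cc1/C=C/COC(=O)/C=C/c1ccccc1C(F)(F)F`: 291 umol/kg

For the measured compounds named here, in a functional assay on the whole organism (strain Kunming) with Mus musculus as the target, in the formalin test, with a stated time of 0.5 h (a lower number here means that less compound is needed, a higher number that more compound is needed for the effect), compound 2 gives 291 umol/kg, the only exact number in this small set. Compound 1 gives >= 180 umol/kg, which is a limit of the assay and not a number.

The next compound to be measured is compound 3 `COc1ccc(/C=C/C(=O)OC/C=C/c2cc(OC)c(OC)cc2OC)cc1`. It carries 4-methoxyphenyl in place of 2-(trifluoromethyl)phenyl on a double-bonded chain carbon bound to a double-bonded chain carbon.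

Going by the values given here, no measured pair shows what a single change does in this assay, so no shift beyond the usual scatter is expected, and the expectation rests on compound 2 at 291 umol/kg. The expected change is a 1.2-fold lower number from compound 2 to compound 3 (0.07 log units; within the scatter). For compound 3 the estimated value is 250 umol/kg. The expected range for compound 3 runs from 90 umol/kg to 700 umol/kg.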

Compound 3, dose for half-maximal effect: 317 umol/kg
Estimate against measurement, compound 3: 1.3-fold (0.10 log units) below; the range from low to high includes it.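

For the compounds shown here, the exchange of 2-(trifluoromethyl)phenyl for 4-methoxyphenyl on a double-bonded chain carbon bound to a double-bonded chain carbon gives a 1.1-fold higher number from compound 2 to compound 3 (0.04 log units; within the scatter) in this assay and is the first single change that can be read in this set. It shows that this position takes these two groups, which differ in their atoms and in the hydrogen-bond acceptor that 4-methoxyphenyl brings, without a shift beyond the scatter. Compound 1 gives >= 180 umol/kg as a limit of the assay and not a number, so it cannot be set against this step: the limit of >= 180 umol/kg in this assay, at which 1 of the 3 values shown sits.

The two groups compared say nothing about how an amine or a carboxylic acid at this place would read in this test. As far as these compounds go, whether unsubstituted phenyl would stay within the scatter of compound 2 also remains open.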